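Ethyl Out, Cyano In on the Double-Bonded Chain

The compounds below may be only part of what the source reports. "The series", "measured", "known", "first", "only" and "open" are said of these compounds alone.

Measured so far:
compound 1 `CCC=C(c1cc(OC)cc(OC)c1)c1ccc(OC)c(OC)c1`: > 10000 nM
compound 2 `COc1ccc(C(=CC#N)c2ccc(OC)c(OC)c2)cc1OC`: 140 nM
compound 3 `COc1cc(C(=CC#N)c2cc(OC)c(OC)c(OC)c2)cc(OC)c1OC`: > 10000 nM

All three compounds were tested in a functional assay on HCT-116 cells (Homo sapiens) for cytotoxicity, read by scintillation counting and thymidine incorporation, with a stated time of 72 h; on this read-out lower numbers stand for stronger inhibition and higher numbers for weaker inhibition. For compound 1 the read-out is only a limit of the assay, > 10000 nM, and not a number. Compound 2 gives a measured value of 140 nM. For compound 3 the result is again a limit, > 10000 nM, so compound 1 stands together with compound 3 at the limit of > 10000 nM in this assay, at which 2 of the 3 values shown sit, while compound 2 is the only one of the three with a number.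

Compound 4 `COc1cc(OC)cc(C(=CC#N)c2ccc(OC)c(OC)c2)c1` is not yet measured. It differs from compound 1 in a single place: cyano in place of ethyl on a double-bonded chain carbon bound to a double-bonded chain carbon. The cyano group is already present in compound 2, which gives 140 nM. It is also present in compound 3, whose result is only a limit. The cyano group on its own therefore does not settle the outcome, and the rest of compound 4 matches compound 1 rather than compound 2.

Starting from the limit of compound 1, the change to cyano is expected to bring a step towards stronger inhibition of roughly an at least 6.6-fold lower number from compound 1 to compound 4 (0.82 log units; beyond the scatter), with considerable uncertainty. Compound 4 is estimated at 1500 nM, expected to lie between 200 nM and 10000 nM.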

Compound 4, half-maximal inhibitory concentration: 18 nM
Estimate against measurement, compound 4: 83-fold (1.92 log units) above; the measured number lies below the stated range.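

In this assay, putting cyano in place of ethyl on a double-bonded chain carbon bound to a double-bonded chain carbon brings an at least 550-fold lower number from compound 1 to compound 4 (2.74 log units; beyond the scatter), which shows that this single place can separate a compound with no measurable number from one with a low number. Ethyl and cyano have the same count of heavy atoms, yet cyano brings a nitrogen, a triple bond and a hydrogen-bond acceptor, so the heavy-atom count alone does not follow this step. The full size of the step cannot be read, and it stands only as a minimum, as compound 1 gives a limit and not a number: the limit of > 10000 nM in this assay, at which 2 of the 4 values shown sit.

The compounds shown leave open which feature of cyano goes with the step, and whether an amine, a carboxylic acid or a longer chain at this carbon would give a result closer to that of ethyl or of cyano. Going by these compounds, compound 3 also carries cyano and gives > 10000 nM, which is a limit, so how far the step depends on the rest of the molecule also stays open.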